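This account rests on a few compounds, and the source may have more. Where it says the series, first, only, none or still open, it means among the compounds named here.

For the measured compounds named here, compound 1 `C[C@@H]1CCCN1c1c(C#N)c2c(N)ncnc2n1C` is one of two compounds measured in an assay on isolated protein for inhibition of Leucine-rich repeat serine/threonine-protein kinase 2 (Homo sapiens), read by TR-FRET and LanthaScreen, with stated times of 50 min and 30 min, in the presence of a further agent that is not named here (on this read-out lower numbers stand for stronger inhibition and higher numbers for weaker inhibition), where compound 1 gives 15 nM. Going by the values given here, its only neighbour is compound 2 `C[C@@H]1CCCN1c1c(C(N)=O)c2c(N)ncnc2n1C`, which in this assay gives 3190 nM; the change a 210-fold higher number from compound 1 to compound 2 (2.33 log units; beyond the scatter) concerns a different position. Compound 3 `Cc1n[nH]cc1Nc1nc(N)c2c(C#N)c(N3CCC[C@H]3C)n(C)c2n1` carries the change ((3-methyl-1H-pyrazol-4-yl)amino in place of hydrogen on an aromatic carbon). Among the compounds with values here, no measured step touches this position, so the step from compound 1 to compound 2 offers no direct guide. The writer expects a modest shift, a 1.9-fold lower number from compound 1 to compound 3 (0.27 log units; within the scatter), and estimates for compound 3 a value of 8 nM, with a range from 1.5 nM to 40 nM.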

Compound 3, half-maximal inhibitory concentration: 42 nM
The estimate for compound 3 lay 5.3-fold (0.72 log units) below the measured number; measured number above the stated range.
By their numbers in this assay, from the lowest: compound 1; then compound 3; then compound 2.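

In this assay the step of a 2.8-fold higher number from compound 1 to compound 3 (0.45 log units; beyond the scatter) shows that this aromatic carbon between two ring nitrogen atoms accepts (3-methyl-1H-pyrazol-4-yl)amino, a group of 7 heavy atoms, at a modest cost, much smaller than the change a 210-fold higher number from compound 1 to compound 2 (2.33 log units; beyond the scatter) at the other position. No measurement offered here accounts for this shift. The compounds shown leave open whether a plain amine or a morpholine on this carbon would give a number closer to that of compound 1. They also leave open whether the methyl on the pyrazole ring contributes to the step.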